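Aryl Swaps at the Cyclopentane Quaternary Carbon and ACAT Inhibition

A few compounds are considered here, and "the series" means these few. Any claim that something is new, unique, unknown or untested is made for them only; others in the source may bear on it.

Measured so far:
Compound 1 `Cc1ccccc1C1(CNC(=O)Nc2c(C(C)C)cccc2C(C)C)CCCC1` gives 17 nM in an assay on microsomes for inhibition of acyl-CoA:cholesterol acyltransferase (Oryctolagus cuniculus); a higher number here means a weaker inhibitor, a lower number a stronger inhibitor.
Compound 2 `CC(C)c1cccc(C(C)C)c1NC(=O)NCC1(c2ccc(NCCO)cc2)CCCC1` gives 25 nM in this assay.

Both compounds share a urea core in which a cyclopentane carbon carries an aryl group, and they differ only in that aryl group. Going by the values given here, compound 2 stands with the higher of the two numbers, but the only measured step, a 1.5-fold higher number from compound 1 to compound 2 (0.17 log units; within the scatter), lies within the scatter, so the two compounds cannot be told apart on these data.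

Compound 3 `COC(=O)c1cccc(C2(CNC(=O)Nc3c(C(C)C)cccc3C(C)C)CCCC2)c1` carries the next aryl variation: 3-(methoxycarbonyl)phenyl in place of 4-((2-hydroxyethyl)amino)phenyl on a saturated ring carbon. Among the compounds with values here, the one step that bears on this position shows that exchanging one aryl group for a quite different one left the number essentially unchanged. A similar outcome is expected here, that is, a step of about a 1.2-fold higher number from compound 2 to compound 3 (0.08 log units; within the scatter), with no change beyond the scatter anticipated. Compound 3 is therefore estimated at 30 nM, within a range from 10 nM to 90 nM.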

Compound 3, half-maximal inhibitory concentration: 34 nM
The estimate for compound 3 lay 1.1-fold (0.05 log units) below the measured number; measured number inside the range.
By their numbers in this assay, from the lowest: compounds 1, 2 and 3 (each within the scatter of the next).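

Putting 3-(methoxycarbonyl)phenyl in place of 4-((2-hydroxyethyl)amino)phenyl removes all hydrogen-bond donors from this group, 0 against 2, yet the change gives a 1.4-fold higher number from compound 2 to compound 3 (0.13 log units; within the scatter) and so cannot be read as a real difference in this assay. The comparison with the first aryl group, a 2.0-fold higher number from compound 1 to compound 3 (0.30 log units; within the scatter) as well, likewise stays inside the scatter, so the three aryl groups on this saturated ring carbon cannot be told apart. Nothing available explains why these different groups give such similar numbers.

The compounds shown leave open whether a carboxylic acid in place of the methyl ester would give a number beyond the scatter. They also leave open what a simple alkyl chain in place of the whole aryl group would do.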